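This account rests on a few compounds, and the source may have more. Where it says the series, first, only, none or still open, it means among the compounds named here.

Compound 1 `Cc1ccc(-c2nc(C)c(COc3ccc4c(c3)OCC4CC(=O)O)s2)cc1`: 54.9%
Compound 2 `Cc1nc(-c2cccc(F)c2)sc1COc1ccc2c(c1)OCC2CC(=O)O`: 56.9%

In a functional assay on CHO cells for agonist activity at Free fatty acid receptor 1 (Homo sapiens), read by FLIPR and calcium flux, tested at 100 nM (on this read-out higher numbers stand for a stronger effect at the one concentration tested and lower numbers for a weaker effect), compound 2 gives 56.9%, and compound 1 gives 54.9%; the two numbers lie within the usual scatter of each other. Compound 3 `Cc1nc(-c2cccc(C(F)(F)F)c2)sc1COc1ccc2c(c1)OCC2CC(=O)O` differs from compound 2 by trifluoromethyl in place of fluoro on an aromatic carbon. Among the measured compounds shown here, the one measured step, a number 2 percentage points higher from compound 1 to compound 2 (within the scatter), also exchanged a group on the same ring and did not move the read-out beyond the scatter. No step beyond the scatter is therefore expected, and the expected step is a number 1.9 percentage points lower from compound 2 to compound 3 (within the scatter). Compound 3 is estimated at 55%, with a range from 40% to 70%.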

Compound 3, a percentage reported as activity, at one concentration (the size of the read-out at that concentration, not a potency): 35.7%
Beside the measured number, compound 3's estimate is 19.3 percentage points above it; the measured number lies below the stated range.
By their numbers in this assay, from the lowest: compound 3; then compounds 1 and 2 (each within the scatter of the next).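

In this assay, this aromatic carbon is not indifferent to what it carries: trifluoromethyl in place of fluoro gives a number 21.2 percentage points lower from compound 2 to compound 3 (beyond the scatter), whereas the earlier exchange on this ring stayed within the scatter. The exchange of 4-methylphenyl for 3-(trifluoromethyl)phenyl gives a number 19.2 percentage points lower from compound 1 to compound 3 (beyond the scatter), so the loss appears from both starting points. Nothing measured here gives a reason for this loss. The compounds shown leave open whether a methoxy group, a chlorine atom or a nitrile at this place would keep the read-out of compound 2. They also leave open whether trifluoromethyl would cost as much on another carbon of this ring.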